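The compounds below may be only part of what the source reports. "The series", "measured", "known", "first", "only" and "open" are said of these compounds alone.

Of the compounds shown here, two have been measured in a functional assay on MCF7 cells (Homo sapiens) for antiproliferative activity; on this read-out lower numbers stand for stronger inhibition and higher numbers for weaker inhibition. Compound 1, with structure `O=c1cc[nH]c(=O)n1C1CN(S(=O)(=O)c2ccccc2[N+](=O)[O-])c2ccccc2CO1`, is the weaker of the pair: in this assay compound 1 gives 50900 nM. Compound 2, with structure `Clc1nc(Cl)c2c(ncn2C2COc3ccccc3CO2)n1`, gives 1250 nM in this assay, a number that lies far below that of compound 1 and beyond the scatter of the method. Compound 1 therefore stands at the top of the two numbers seen so far.

The compound still to be measured is compound 3, with structure `O=c1cc[nH]c(=O)n1C1CN(S(=O)(=O)c2ccc([N+](=O)[O-])cc2)c2ccccc2CO1`. It differs from compound 1 in one place, and the difference is counted as 4-nitrophenyl in place of 2-nitrophenyl on a sulfonyl sulfur. The atoms are the same in both; only the nitro group sits elsewhere on the ring that is bound to the sulfonyl sulfur.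

Going by the values given here, no measured pair shows what such a change does to this read-out, so nothing in the data points one way or the other. The expectation is that compound 3 stays near compound 1, with a 1.3-fold lower number from compound 1 to compound 3 (0.10 log units; within the scatter) not beyond the scatter. Compound 3 is thus estimated at 40000 nM, in a range from 12000 nM to 130000 nM.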

Compound 3, half-maximal inhibitory concentration: 44300 nM
Compound 3: the middle estimate sits 1.1-fold (0.04 log units) below what was measured; low and high end bracket the measured number.
By their numbers in this assay, from the lowest: compound 2; then compounds 3 and 1 (each within the scatter of the next).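

Read in this assay, the step from the 2-nitrophenyl to the 4-nitrophenyl group on the sulfonyl sulfur is a 1.1-fold lower number from compound 1 to compound 3 (0.06 log units; within the scatter), and this is the first measured pair that speaks to this place on the shared core. It shows that, on the core of compound 1 and for these two groups, where the nitro group sits on the ring bound to the sulfonyl sulfur makes no difference that this read-out can separate from the scatter of the method, so neither compound of the pair can be ranked above the other. Nothing available here offers a measured property that bears on this result or could account for it.

From the compounds shown here alone, this single pair says nothing about a ring that carries something other than a nitro group, so whether an amine, a carboxylic acid or a methoxy group in its place, or a plain phenyl on the sulfonyl sulfur, would shift the number remains open. Going by these compounds, it also remains open whether moving the nitro group would leave the number just as undisturbed on a different core, since the pair covers only the core of compound 1.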